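Exchanging the methoxyphenyl for a difluorophenyl on the carbonyl

The compounds below may be only part of what the source reports. "The series", "measured", "known", "first", "only" and "open" are said of these compounds alone.

compound 1 `COc1cc(-c2cc(/C=C/C(=O)c3ccc(Cl)c(Cl)c3)[nH]n2)cc(OC)c1OC`: -7%
compound 2 `COc1ccc(-c2cc(/C=C/C(=O)c3cc(OC)c(OC)c(OC)c3)[nH]n2)cc1OC`: -16%
compound 3 `COc1ccc(C(=O)/C=C/c2cc(-c3cc(OC)c(OC)c(OC)c3)n[nH]2)cc1`: 1%

In a functional assay on K562 cells (Homo sapiens) for cytotoxicity, read by sulforhodamine B assay, with a stated time of 48 h, tested at 100 uM (a lower number here means a stronger effect, a higher number a weaker effect of the compound at the concentration tested), compound 1 gives -7%, compound 2 gives -16% and compound 3 gives 1%. Going by the values given here, compound 3 holds the highest of the three numbers, but its gap to compound 1 lies within the scatter; only compound 2 lies beyond it, and no single-point step links compound 2 to compound 3. Among the compounds with values here, the one measured step, a number 8 percentage points higher from compound 1 to compound 3 (within the scatter), is the only comparison that changes the aryl group on the carbonyl carbon, and it stayed within the scatter.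

Compound 4 `COc1cc(-c2cc(/C=C/C(=O)c3ccc(F)c(F)c3)[nH]n2)cc(OC)c1OC` differs from compound 3 in this way: 3,4-difluorophenyl in place of 4-methoxyphenyl on a carbonyl carbon. Within the data shown here, compound 1, carrying a 3,4-dichlorophenyl at the same place, gave -7%, so the closest precedent points to a number near zero. Because a number 8 percentage points higher from compound 1 to compound 3 (within the scatter) was within the scatter, the step of a number 4 percentage points lower from compound 3 to compound 4 (within the scatter) is expected to be small in either direction. Compound 4 is therefore estimated at -3%, with a range from -18% to 12%.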

Compound 4, a percentage reported as activity, at one concentration (the size of the read-out at that concentration, not a potency): -7%
For compound 4 the middle estimate is 4 percentage points above the measured one; measured number inside the range.
By their numbers in this assay, from the lowest: compounds 2, 1, 4 and 3 (each within the scatter of the next, the first and the last beyond it).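

In this assay the aryl group on the carbonyl carbon now has a third measured form, and the two new comparisons both stay within the scatter: there is a number 8 percentage points lower from compound 3 to compound 4 (within the scatter), and no change at the digits printed from compound 1 to compound 4 (within the scatter). The second of these is new in kind, as it exchanges one dihalogenated phenyl for another, where the earlier step had only set 4-methoxyphenyl against 3,4-dichlorophenyl; across these three aryl groups, with the rest of the structure unchanged, the read-out at this single concentration does not separate the compounds. Nothing measured here offers an explanation for this.

Going by these compounds, what a piperidine, or a phenyl carrying a carboxylic acid, would give on the same carbonyl carbon stays open. So does whether these three compounds would separate at lower concentrations, since one concentration gives no potency.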